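The compounds below may be only part of what the source reports. "The series", "measured", "known", "first", "only" and "open" are said of these compounds alone.

Compounds measured in a functional assay on PC-3 cells (Homo sapiens) for inhibition; on this read-out higher numbers stand for weaker inhibition and lower numbers for stronger inhibition:
compound 1 `Cc1c(C(=O)N/N=C\c2ccc(O)cc2)oc2cccc(O)c12` — 21700 nM
compound 2 `Cc1ccc(O)c(/C=N\NC(=O)c2oc3cccc(O)c3c2C)c1` — 7350 nM
compound 3 `Cc1c(C(=O)N/N=C\c2cccc(O)c2)oc2cccc(O)c12` — 17600 nM

Compound 3 stands second highest of the three numbers; against compound 1 it sits within the scatter, as a 1.2-fold lower number from compound 1 to compound 3 (0.09 log units; within the scatter) shows, while against compound 2 the gap is beyond the scatter, see a 2.4-fold higher number from compound 2 to compound 3 (0.38 log units; beyond the scatter). The step of a 3.0-fold lower number from compound 1 to compound 2 (0.47 log units; beyond the scatter) points the same way.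

Compound 4 `COc1ccccc1/C=N\NC(=O)c1oc2cccc(O)c2c1C` is the next compound, and the change from compound 3 is 2-methoxyphenyl in place of 3-hydroxyphenyl on a carbon with a double bond to nitrogen. Among the compounds with values here, no measured step swaps a hydroxyl for a methoxy at this position, so only the step to compound 2 bears on it, and that one was modest. The expected outcome is a small step, a 1.2-fold lower number from compound 3 to compound 4 (0.07 log units; within the scatter), not clearly beyond the scatter. For compound 4 the estimate in this assay is 15000 nM, ranging from 6000 nM to 40000 nM.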

Compound 4, half-maximal inhibitory concentration: 32700 nM
Estimate against measurement, compound 4: 2.2-fold (0.34 log units) below; the range from low to high includes it.
By their numbers in this assay, from the lowest: compound 2; then compounds 3, 1 and 4 (each within the scatter of the next).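

In this assay, 2-methoxyphenyl on a carbon with a double bond to nitrogen does not separate from 3-hydroxyphenyl (a 1.9-fold higher number from compound 3 to compound 4 (0.27 log units; within the scatter)) or 4-hydroxyphenyl (a 1.5-fold higher number from compound 1 to compound 4 (0.18 log units; within the scatter)). This group therefore has no hydroxyl, yet its number stays within the scatter of both hydroxyphenyl compounds. Only 2-hydroxy-5-methylphenyl stands apart from it (a 4.4-fold higher number from compound 2 to compound 4 (0.65 log units; beyond the scatter)), and no measured evidence accounts for this. As far as these compounds go, compound 4 lacks both the hydroxyl and the methyl of 2-hydroxy-5-methylphenyl, so which of them goes with the lower number of compound 2 stays open. From the compounds shown here alone, how an amine or a carboxylic acid on this phenyl would read is also open.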